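A few compounds are considered here, and "the series" means these few. Any claim that something is new, unique, unknown or untested is made for them only; others in the source may bear on it.

Compound 1 `O=C1C=C(NC2CCCC2)C(=O)c2c1nc1n2[C@H]2OC[C@@H](O)[C@H]2OC1` in a functional assay on HeLa cells (Homo sapiens) for inhibition, read by sulforhodamine B assay (on this read-out higher numbers stand for weaker inhibition and lower numbers for stronger inhibition), gives > 16000 nM, which is a limit of the assay and not a number. Compound 2 `O=C1C(N2CCC2)=CC(=O)c2c1nc1n2[C@H]2OC[C@@H](O)[C@H]2OC1` in this assay likewise gives > 16000 nM, again a limit. Among the compounds with values here, neither compound reached a measurable value; the series so far shows only (the limit of > 16000 nM in this assay, at which 2 of the 2 values shown sit). Compound 3 `O=C1C=C(Nc2ccc(I)cc2)C(=O)c2c1nc1n2[C@H]2OC[C@@H](O)[C@H]2OC1` differs from compound 1 by 4-iodophenyl in place of cyclopentyl on an amine nitrogen. Within the data shown here, no step between measured compounds is at hand, so nothing fixes the size or direction of this change; the expectation is for no step beyond the usual scatter a number no higher from compound 1 to compound 3 (the limit leaves the size open). Compound 3 is therefore estimated at 16000 nM, with a range from 4000 nM to 64000 nM, and a limit rather than a number is the likelier outcome.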

Compound 3, half-maximal inhibitory concentration: 4070 nM
Compound 3: the middle estimate sits 3.9-fold (0.59 log units) above what was measured; the measured number falls inside the stated range.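

In this assay, 4-iodophenyl in place of cyclopentyl on an amine nitrogen gives an at least 3.9-fold lower number from compound 1 to compound 3 (0.59 log units; beyond the scatter). This substituent can therefore move the read-out off the limit, which the earlier compounds could not show: the limit of > 16000 nM in this assay, at which 2 of the 3 values shown sit.

As far as these compounds go, the value of compound 1 is a limit, so the full size of the step stays open. From the compounds shown here alone, whether the aromatic ring or the iodine carries the step also stays open, as both enter together; a plain phenyl or a 4-chlorophenyl on the same nitrogen would separate the two.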